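The compounds below may be only part of what the source reports. "The series", "measured", "known", "first", "only" and "open" are said of these compounds alone.

Working notes on the series.

Among the measured compounds shown here, compound 2 `COc1ccc2[nH]cc(C(=O)/C(C#N)=C/C=C(\Cl)c3ccc(Br)cc3)c2c1` gives the highest of the three numbers measured so far in a functional assay for inhibition, read by Griess assay, with a stated time of 150 min, tested at 1 mM (on this read-out higher numbers stand for more inhibition at the one concentration tested (going by the name of the read-out) and lower numbers for less inhibition), at 76.7%. Compound 1 `COc1ccc2[nH]cc(C(=O)/C(C#N)=C/C=C(\Cl)c3ccc(OC)c(OC)c3)c2c1` in this assay reaches 74.2%, and the difference a number 2.5 percentage points higher from compound 1 to compound 2 (within the scatter) does not separate the two. For the measured compounds named here, compound 3 `COc1ccc(/C(Cl)=C/C=C(\C#N)C(=O)c2c[nH]c3ccc(OC)cc23)cc1` in this assay gives 41.6%; the drops a number 32.6 percentage points lower from compound 1 to compound 3 (beyond the scatter) and a number 35.1 percentage points lower from compound 2 to compound 3 (beyond the scatter) are the only steps in the set that clearly exceed the scatter. Both of these steps alter the pendant phenyl ring.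

Compound 4 `N#C/C(=C\C=C(/Cl)c1ccc(Br)cc1)C(=O)c1c[nH]c2ccc(Br)cc12` differs from compound 2 by bromo in place of methoxy on an aromatic carbon, a change at the fused two-ring system rather than at the pendant phenyl. Going by the values given here, none of the measured steps touches that ring; the methoxy there is common to compounds 1, 2 and 3, so no step bears directly on this change. Among the compounds with values here, the only bromo-related step on record, a number 2.5 percentage points higher from compound 1 to compound 2 (within the scatter), lay within the scatter. The step from compound 2 to compound 4 is therefore expected to stay near the scatter, a number 6.7 percentage points lower from compound 2 to compound 4 (within the scatter), with a wider uncertainty than usual. Compound 4 in this assay is estimated at 70%, in the range 50% to 85%.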

Compound 4, a percentage reported as inhibition, at one concentration (the size of the read-out at that concentration, not a potency): 67.5%
For compound 4 the middle estimate is 2.5 percentage points above the measured one; measured number inside the range.
By their numbers in this assay, from the lowest: compound 3; then compounds 4, 1 and 2 (each within the scatter of the next).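

Among the compounds shown here, compounds 1, 2 and 3 all carry methoxy on this aromatic carbon of the fused system, so compound 4 gives the first reading of a change at this position. In this assay, with the 4-bromophenyl kept in place, bromo in place of methoxy gives a number 9.2 percentage points lower from compound 2 to compound 4 (within the scatter), so methoxy is not needed here to keep the number within the scatter of compound 2. This holds for this one pair and this one replacement only. No measurement on hand explains the result.

Only methoxy and bromo are shown at this position, so it remains open how an amine or a carboxylic acid there would read. Also open, from the compounds shown here alone, is whether the same change would hold with the pendant ring of compound 1 or of compound 3.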